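The source may hold more compounds than are shown below. What is called first, only, known or untested is meant among the compounds shown, and "the series" means these compounds.

Compound 1 `CCCCCCCCOc1nc(N)nc2c1ncn2/C=C1/CC1(CO)CO`: in an ADME assay on CCRF-HSB-2 cells (Homo sapiens) for cytotoxicity, with a stated time of 7 days (on this read-out lower numbers stand for higher toxicity in this test and higher numbers for lower toxicity in this test), compound 1 gives > 20000 nM, which is a limit of the assay and not a number.
Compound 2 `CCCCSc1nc(N)nc2c1ncn2/C=C1/CC1(CO)CO`: in this assay compound 2 gives 89000 nM.
Compound 3 `Nc1nc(N2CCCC2)c2ncn(/C=C3/CC3(CO)CO)c2n1`: in this assay compound 3 gives > 20000 nM, again a limit rather than a number.

Among the compounds with values here, compound 2 therefore stands as the only measured number among the three; the other two values are limits, (the limit of > 20000 nM in this assay, at which 2 of the 3 values shown sit). With two limits among three values, none of the steps between the measured compounds can be read in size: a step that the limit leaves unreadable from compound 1 to compound 2, a step that the two limits leave unreadable from compound 1 to compound 3 and a step that the limit leaves unreadable from compound 2 to compound 3 all remain unreadable.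

Compound 4 `CCCCCCCCSc1nc(N)nc2c1ncn2/C=C1/CC1(CO)CO` has not yet been measured in this assay. It differs from compound 2 in one place: butyl in place of hydrogen on a saturated chain carbon, four bonds along the chain from a sulfur. Within the data shown here, no measured step of known size bears on this lengthening of the chain on the sulfur, since every step involving compound 1 or compound 3 is hidden by a limit. The expectation is accordingly cautious and anchored on compound 2 alone, with no step beyond the scatter expected and a real chance that only a limit is reported. Compound 4 is estimated at 60000 nM, with a range from 15000 nM to 250000 nM. This corresponds to an expected 1.5-fold lower number from compound 2 to compound 4 (0.17 log units; within the scatter).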

Compound 4, half-maximal cytotoxic concentration: 60000 nM
Beside the measured number, compound 4's estimate shows no gap at the digits printed; the range from low to high includes it.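

In this assay, the lengthening of the chain on the sulfur gives the first step of readable size among these compounds: a 1.5-fold lower number from compound 2 to compound 4 (0.17 log units; within the scatter). Butyl in place of hydrogen, four bonds along the chain from a sulfur, therefore leaves the read-out within the usual scatter, and the butylsulfanyl and octylsulfanyl chains cannot be told apart on this measure. Compound 1 and compound 3 each remain at a limit of the assay and not a number, and the steps from them to compound 4 cannot be read, so the comparisons of octylsulfanyl with octyloxy and with pyrrolidin-1-yl stay closed: the limit of > 20000 nM in this assay, at which 2 of the 4 values shown sit.

The compounds shown leave open whether a chain on the sulfur shorter than butyl, such as methyl or ethyl, or a longer chain such as dodecyl, would give a step beyond the scatter. Also open, going by these compounds, is whether an octylamino group in place of octylsulfanyl, or a chain carrying a carboxylic acid, would give a readable step in this assay.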